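A few compounds are considered here, and "the series" means these few. Any claim that something is new, unique, unknown or untested is made for them only; others in the source may bear on it.

Values in a functional assay on NCI-H460 cells (Homo sapiens) for cytotoxicity, read by MTT assay, with a stated time of 3 days; on this read-out lower numbers stand for stronger inhibition and higher numbers for weaker inhibition:
- compound 1 `N#Cc1c(NNC(N)=S)nc(SCc2nc3ccccc3[nH]2)nc1-c1ccccc1`: 3.37 nM
- compound 2 `N#Cc1c(-c2ccccc2)nc(SCc2nc3ccccc3[nH]2)nc1N1CCNCC1`: 7.35 nM
- compound 3 `CN1CCN(c2nc(SCc3nc4ccccc4[nH]3)nc(-c3ccccc3)c2C#N)CC1`: 2.84 nM

Compound 3 and compound 1 share the low end of this small set, within the scatter of each other: a 1.2-fold lower number from compound 1 to compound 3 (0.07 log units; within the scatter). Compound 2 lies apart from compound 3, with a 2.6-fold lower number from compound 2 to compound 3 (0.41 log units; beyond the scatter).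

The compound still unmeasured is compound 4 `N#Cc1c(-c2ccccc2)nc(SCc2nc3ccccc3[nH]2)nc1N1CCN(S(=O)(=O)c2ccccc2)CC1`, which has phenylsulfonyl in place of methyl on an amine nitrogen in a ring.

Among the compounds with values here, only one measured step changes that same nitrogen, namely the hydrogen-to-methyl exchange, and it was modest: a 2.6-fold lower number from compound 2 to compound 3 (0.41 log units; beyond the scatter). Replacing the whole group on the aromatic carbon also moved the number only modestly, with a 2.2-fold higher number from compound 1 to compound 2 (0.34 log units; beyond the scatter). Within the data shown here, no measured step places a sulfonyl group, or a group of this size, on that nitrogen, so the evidence for direction is thin. A modest step towards a higher number, meaning weaker inhibition, is expected, and a wide margin is kept on both sides.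

The expected change is a 2.1-fold higher number from compound 3 to compound 4 (0.32 log units; beyond the scatter). For compound 4 the estimated value is 6 nM, with an expected range of 1.5 nM to 25 nM.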

Compound 4, half-maximal inhibitory concentration: 4.6 nM
Beside the measured number, compound 4's estimate is 1.3-fold (0.12 log units) above it; low and high end bracket the measured number.
By their numbers in this assay, from the lowest: compounds 3, 1, 4 and 2 (each within the scatter of the next, the first and the last beyond it).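

In this assay, putting phenylsulfonyl, with its six-membered aromatic ring, in place of the single carbon of methyl on the amine nitrogen gives a 1.6-fold higher number from compound 3 to compound 4 (0.21 log units; within the scatter) and, set against hydrogen on the same nitrogen, a 1.6-fold lower number from compound 2 to compound 4 (0.20 log units; within the scatter) as its second reading. The earlier compounds shown here carried only hydrogen or methyl at this position, where the exchange gave a 2.6-fold lower number from compound 2 to compound 3 (0.41 log units; beyond the scatter) and so lay beyond the scatter, whereas compound 4 now sits within the scatter of both compounds and shows that this nitrogen can bear a far larger group, with 2 hydrogen-bond acceptors, and still keep a number in the same narrow range. Nothing measured here offers an explanation for this outcome.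

The compounds shown leave open whether the sulfonyl link or the phenyl ring matters more, since a methylsulfonyl or a benzyl group on the same nitrogen would separate the two. They also leave open how a longer alkyl chain or a chain ending in a carboxylic acid would read at this position, as every group seen on this nitrogen so far carries no net charge.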